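The source may report more compounds than this note shows. Statements on the series, on what has been measured and on what is new or still open speak of the compounds shown alone.

Measured so far:
compound 1 `COc1cc(-c2cnn3cc(OC)c(C(C)(C)O)nc23)ccn1` gives 92%
compound 2 `COc1cn2ncc(-c3ccnc(OC(C)C)c3)c2nc1-c1cnn(C)c1` gives 50%
compound 3 `COc1cn2ncc(-c3ccnc(OC4CC4)c3)c2nc1-c1cnn(C)c1` gives 32%
Not yet measured:
compound 4 `COc1cc(-c2cnn3cc(OC)c([C@H]4COC(C)(C)C4)nc23)ccn1`

All three numbers come from an ADME assay on microsomes from liver (Rattus norvegicus) for metabolic stability, with a stated time of 60 min, tested at 1 uM (a higher number here means that more of the compound is left, a lower number that less of the compound is left), and compound 1 stands highest of them, with both others lower by more than the scatter.

The step to follow runs from compound 1 to compound 4: a group of 7 heavy atoms (6 carbon, 1 oxygen; one five-membered non-aromatic ring with 1 hetero atom) in place of a group of 4 heavy atoms (3 carbon, 1 oxygen; no ring), on an aromatic carbon. The group with the five-membered non-aromatic ring replaces 1-hydroxy-1-methylethyl, and the rest of the core of compound 1 stays unchanged.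

For the measured compounds named here, the only measured step, a number 18 percentage points lower from compound 2 to compound 3 (beyond the scatter), is modest but beyond the scatter. It concerns the group on oxygen at another place, so it gives no direct reading of this change. Compound 2 (50%) and compound 3 (32%) both lack 1-hydroxy-1-methylethyl, but each differs from compound 1 in more than one place, which makes them a loose guide only. Going by the values given here, no measured pair isolates the change at hand.

A drop of modest to large size is therefore expected in this assay, with wide uncertainty. The estimated step is a number 30 percentage points lower from compound 1 to compound 4 (beyond the scatter), beyond the scatter. For compound 4 the expected value is 62%, with an estimated range from 35% to 87%.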

Compound 4, percent of the compound remaining: 30%
Estimate against measurement, compound 4: 32 percentage points above; measured number outside the range, below it.
By their numbers in this assay, from the lowest: compounds 4 and 3 (each within the scatter of the next); then compound 2; then compound 1.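

In this assay, for the compounds shown here, placing the group with the five-membered non-aromatic ring on the aromatic carbon ortho to a methoxy group, in place of 1-hydroxy-1-methylethyl, gives a number 62 percentage points lower from compound 1 to compound 4 (beyond the scatter) as the first reading at this position. The rest of the core of compound 1 stays unchanged, so this large step belongs to this single exchange, and the percent remaining at this position is clearly sensitive to the group it carries. No measurement shown gives a reason for the step.

The exchange removes the hydrogen-bond donor, adds the ring and enlarges the group all at once, so the compounds shown cannot say which of these changes goes with the step; tert-butyl or 1-methoxy-1-methylethyl on the same aromatic carbon would help to separate them. Going by these compounds alone, also open are the effect of the defined stereocentre, since only one form of the ring group appears here, and whether an open-chain ether or an amine at this position would behave in the same way.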